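Cytotoxicity notes: ester to amide on the shared core

The source may hold more compounds than are shown below. What is called first, only, known or untested is meant among the compounds shown, and "the series" means these compounds.

Measured in a toxicity assay on NIH3T3 cells (Mus musculus) for cytotoxicity, read by resazurin assay; on this read-out higher numbers stand for an effect only at larger amounts of compound and lower numbers for an effect already at smaller amounts:
compound 1 `COC(=O)c1ccc(NCc2cncn2Cc2cccc(C)c2)cc1-c1ccccc1` gives > 10000 nM
compound 2 `CC(C)OC(=O)c1ccc(NCc2cncn2Cc2ccc(-c3ccccc3)cc2)cc1-c1ccccc1` gives > 10000 nM
compound 3 `Cc1cccc(-c2cccc(NCc3cncn3Cc3ccccc3)c2)c1` gives > 1000 nM

In this assay compound 2 stands at a limit, not at a number. Compound 1 sits at the same limit, (the limit of > 10000 nM in this assay, at which 2 of the 3 values shown sit). Compound 3 sits at a limit as well, (the limit of > 1000 nM in this assay, at which 1 of the 3 values shown sits). Among the measured compounds shown here, no pair of measured compounds differs in only one place, so no step size can be read from these three.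

Compound 4 `CN(C)C(=O)c1ccc(NCc2cncn2Cc2ccc(-c3ccccc3)cc2)cc1-c1ccccc1` is not yet measured. It differs from compound 2 by dimethylamino in place of isopropoxy on a carbonyl carbon. The step that the limit leaves unreadable from compound 2 to compound 4 is expected to stay within the scatter, with no direction. Compound 4 is expected to give 15000 nM, between 5000 nM and 50000 nM, most probably again only a limit.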

Compound 4, half-maximal effective concentration: > 1000 nM
Compound 4: no number, only a limit; the forecaster's own chance of this, stated with the estimate: 80%; the middle value is on the limit's open side.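

Compound 2 and compound 4 both give only limits, and the step between them cannot be read. The compounds shown leave open whether dimethylamino in place of isopropoxy on a carbonyl carbon changes the read-out at all.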